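Benzyl on the aromatic nitrogen of compound 1

A few compounds are considered here, and "the series" means these few. Any claim that something is new, unique, unknown or untested is made for them only; others in the source may bear on it.

Measured compounds (a functional assay on cells (Platelet, Homo sapiens) for inhibition; on this read-out higher numbers stand for weaker inhibition and lower numbers for stronger inhibition):
- compound 1 `CCOC(=O)c1cccc(-c2n[nH]c3ccccc23)c1` gives > 10000 nM
- compound 2 `CCOC(=O)c1ccc(-c2nn(C)c3ccccc23)cc1` gives > 10000 nM
- compound 3 `CCOC(=O)c1ccc(-c2nn(Cc3cccc(Cl)c3)c3ccccc23)cc1` gives > 10000 nM

Compound 1 gives > 10000 nM as a limit of the assay and not a number. The other measured compounds offer no firmer reference (the limit of > 10000 nM in this assay, at which 3 of the 3 values shown sit).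

Compound 4 `CCOC(=O)c1cccc(-c2nn(Cc3ccccc3)c3ccccc23)c1` carries benzyl in place of hydrogen on an aromatic nitrogen of a five-membered aromatic ring with 2 nitrogen (benzyl in place of hydrogen on an aromatic nitrogen). The nearest measured change is on a chain at an aromatic nitrogen (a step that the two limits leave unreadable from compound 2 to compound 3), and it has no readable size. Compound 3 carries 3-chlorophenyl on that chain and gives > 10000 nM as a limit. The measured step therefore sets neither a size nor a direction for the change to compound 4. With compound 1 at a limit, any readable result in this assay would have to mean stronger inhibition, and a further limit remains about as likely as a number. A modest move is the most that can be expected.

The estimated step is an at least 1.2-fold lower number from compound 1 to compound 4 (0.09 log units; that floor lies within the scatter) and carries wide uncertainty. The expected value for compound 4 is 8000 nM with an estimated range from 800 nM to 30000 nM as its likely span.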

Compound 4, half-maximal inhibitory concentration: > 10000 nM
Compound 4: no number, only a limit (the forecaster's own chance of this, stated with the estimate: 50%); at least 1.2-fold (0.09 log units) between middle value and limit.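

In this assay compound 4 gives > 10000 nM, a limit and not a number. Compound 1 also stands at a limit, so no step from compound 1 to compound 4 can be read: the limit of > 10000 nM in this assay, at which 4 of the 4 values shown sit.

The compounds shown leave open whether benzyl on the aromatic nitrogen changes inhibition at all.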